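Oxime in place of oxazole on an anilinomethyl-imidazoline scaffold

The source may hold more compounds than are shown below. What is called first, only, known or untested is meant among the compounds shown, and "the series" means these compounds.

Three measured compounds share a core and differ only in the group on the aromatic carbon. Compound 1 `Cc1nc(-c2ccccc2NCC2=NCCN2)co1` gives 324 nM in a functional assay for activation of Alpha-1A adrenergic receptor (Homo sapiens), read by calcium flux (a lower number here means that less compound is needed, a higher number that more compound is needed for the effect), the highest number of the three. Compound 2 `Cc1cccnc1-c1ccccc1NCC1=NCCN1` gives 24.6 nM and compound 3 `Nc1nccc(-c2ccccc2NCC2=NCCN2)n1` gives 42.7 nM, both beyond the scatter from compound 1. Compound 4 `CO/N=C(\C)c1ccccc1NCC1=NCCN1` has not yet been measured. It differs from compound 1 by a group of 5 heavy atoms (3 carbon, 1 nitrogen, 1 oxygen; no ring) in place of a group of 6 heavy atoms (4 carbon, 1 nitrogen, 1 oxygen; one five-membered aromatic ring with 2 hetero atoms), on an aromatic carbon. Among the compounds with values here, no step between measured compounds isolates this change, so the group with one five-membered aromatic ring leaving and the group with no ring entering offers no precedent. The step of a 1.2-fold lower number from compound 1 to compound 4 (0.06 log units; within the scatter) is expected to stay within the scatter. Compound 4 is estimated at 280 nM, between 70 nM and 1100 nM.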

Compound 4, half-maximal effective concentration: 20.9 nM
The estimate for compound 4 lay 13-fold (1.13 log units) above the measured number; the whole stated range lies above it.
By their numbers in this assay, from the lowest: compounds 4, 2 and 3 (each within the scatter of the next, the first and the last beyond it); then compound 1.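

Taking the 2-methyl-1,3-oxazol-4-yl group off this aromatic carbon and putting a group with no ring in its place gives a 16-fold lower number from compound 1 to compound 4 (1.19 log units; beyond the scatter) in this assay. The earlier compounds shown here all carry an aromatic ring at this place, and this step shows that a ring is not required there for a low number. No measurement shown here accounts for the size of this step.

On these data alone, how an acetyl group or an oxime with a free hydroxyl would compare at this place remains open. So does the outcome with the opposite geometry at the double bond.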